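Moving the Halogen on the Pendant Aryl Ring

The source may hold more compounds than are shown below. What is called first, only, known or untested is meant among the compounds shown, and "the series" means these compounds.

Three close relatives of one shared core are compared here. Going by the values given here, compound 1 `COc1nc(-c2cccc(Cl)c2)ccc1[C@@H](c1ccccc1)[C@@](O)(CCN(C)C)c1cccc2ccccc12` is the first; in a toxicity assay on HeLa cells (Homo sapiens) for cytotoxicity (a lower number here means that less compound is tolerated, a higher number that more compound is tolerated), compound 1 gives "nd" (no result reported), so no number stands for it. Compound 2 `COc1nc(-c2ccc(Br)cc2)ccc1[C@@H](c1ccccc1)[C@@](O)(CCN(C)C)c1cccc2ccccc12` carries a 4-bromophenyl group. In this assay compound 2 gives > 64 ug/mL, which is a limit of the assay rather than a measured number. Among the compounds with values here, compound 2 thus sits at the limit of > 64 ug/mL in this assay, at which 1 of the 2 values shown sits, the only value known. Compound 3 `COc1nc(-c2ccccc2Cl)ccc1[C@@H](c1ccccc1)[C@@](O)(CCN(C)C)c1cccc2ccccc12` differs from compound 2 in one place: 2-chlorophenyl in place of 4-bromophenyl on an aromatic carbon. Within the data shown here, no measured step between two compounds is available to gauge what such a swap does. With only a limit to go by, the step of a number no higher from compound 2 to compound 3 (the limit leaves the size open) is expected to be small, most likely none beyond the usual scatter. Compound 3 is therefore estimated at 64 ug/mL, within 32 ug/mL to 128 ug/mL, and the result is expected quite possibly to come back again as a limit only.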

Compound 3, half-maximal cytotoxic concentration: > 64 ug/mL
Compound 3: only a limit was reported; the forecaster's own chance of this, stated with the estimate: 70%; the middle value lies on the limit itself.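

Compound 2 and compound 3 both end at a limit of the assay, not at a number, so no step between them can be read: the limit of > 64 ug/mL in this assay, at which 2 of the 3 values shown sit.

The compounds shown leave open how much compound is tolerated in this assay beyond that limit, and whether 2-chlorophenyl in place of 4-bromophenyl changes it at all.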